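This account rests on a few compounds, and the source may have more. Where it says the series, first, only, none or still open, it means among the compounds named here.

Measured compounds in a functional assay on MCF7 cells (Homo sapiens) for antiproliferative activity, read by MTT assay, with a stated time of 24 h; a lower number here means a stronger inhibitor, a higher number a weaker inhibitor:

Compound 1 `Clc1ccc(C2CC(c3ccccc3)=NN2c2ccc(-c3ccccc3)nn2)cc1` gives 100000 nM.
Compound 2 `Clc1ccc(C2=NN(c3ccc(-c4ccccc4)nn3)C(c3ccc(Cl)cc3)C2)cc1` gives 8800 nM.
Compound 3 `COc1ccc(C2=NN(c3ccc(-c4ccccc4)nn3)C(c3ccccc3)C2)cc1` gives only a limit of the assay, > 100000 nM.

Within the data shown here, compound 3 therefore stands at the edge of what the numbers show: its result in this assay is a limit, not a measured number, and it is the one compound of the three that sits at the limit of > 100000 nM in this assay, at which 1 of the 3 values shown sits. Compound 4 `COc1ccc(C2=NN(c3ccc(-c4ccccc4)nn3)C(c3ccc(Cl)cc3)C2)cc1` differs from compound 3 in a single place: chloro in place of hydrogen on an aromatic carbon. The same change has been measured once among these compounds, from compound 1 to compound 2, where it gave an 11-fold lower number from compound 1 to compound 2 (1.06 log units; beyond the scatter). Among the measured compounds shown here, no other measured step bears on the present one. A move of a similar size toward stronger inhibition in this assay is therefore expected, but compound 3 offers only a limit as the starting point, so the landing place of compound 4 is less certain than the size of the earlier step would suggest, and a limit remains possible for compound 4 as well. Compound 4 is expected to give 20000 nM, with a likely range from 5000 nM to 100000 nM. The expected step is an at least 5.0-fold lower number from compound 3 to compound 4 (0.69 log units; beyond the scatter).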

Compound 4, half-maximal inhibitory concentration: 58000 nM
Compound 4: the middle estimate sits 2.9-fold (0.46 log units) below what was measured; measured number inside the range.
By their numbers in this assay, from the lowest: compound 2; then compounds 4 and 1 (each within the scatter of the next).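

In this assay, chloro in place of hydrogen on the methoxy-bearing core gives an at least 1.7-fold lower number from compound 3 to compound 4 (0.23 log units; that floor lies within the scatter); this is a floor only, as the starting value of compound 3 is a limit, so the change is not shown to exceed the scatter on this second core. With the 4-chlorophenyl held in place, methoxy in place of chloro gives a 6.6-fold higher number from compound 2 to compound 4 (0.82 log units; beyond the scatter), so among these compounds the second chloro of compound 2 is not matched by methoxy. Methoxy in place of hydrogen gives a 1.7-fold lower number from compound 1 to compound 4 (0.24 log units; within the scatter), so in this assay that change cannot be told apart from the scatter.

Whether the chloro step has the same size on both cores stays open: the same change on two cores in this assay, an 11-fold lower number (1.06 log units; beyond the scatter) from compound 1 to compound 2 and an at least 1.7-fold lower number (0.23 log units; that floor lies within the scatter) from compound 3 to compound 4; the limit leaves it open whether they differ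

The compounds shown also leave open how an amine or a carboxylic acid would read at the place now held by chloro or methoxy.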